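A few compounds are considered here, and "the series" means these few. Any claim that something is new, unique, unknown or untested is made for them only; others in the source may bear on it.

Compounds 1 to 3 share one core and differ in the aromatic ring on a carbon with a double bond to nitrogen. In a functional assay on A549 cells (Homo sapiens) for antiproliferative activity, read by MTT assay, with a stated time of 72 h (on this read-out higher numbers stand for weaker inhibition and lower numbers for stronger inhibition), compound 1 (`O=C(N/N=C/c1ccc([N+](=O)[O-])cc1)Nc1ccc(Oc2ccnc3[nH]ccc23)c(F)c1`) gives 20 nM. Compound 3 (`O=C(N/N=C/c1ccc(Cl)c(Cl)c1)Nc1ccc(Oc2ccnc3[nH]ccc23)c(F)c1`) gives 2650 nM, the higher of the two numbers available, which makes it the weaker inhibitor of that pair. Compound 2 (`O=C(N/N=C/c1cccc(Cl)c1Cl)Nc1ccc(Oc2ccnc3[nH]ccc23)c(F)c1`) is recorded as "not active" (no number reported), so it cannot be placed on the numerical scale.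

Compound 4 (`O=C(N/N=C/c1ccc(O)c(Br)c1)Nc1ccc(Oc2ccnc3[nH]ccc23)c(F)c1`) has not yet been measured. It differs from compound 3 in a single place, on a carbon with a double bond to nitrogen: 3-bromo-4-hydroxyphenyl in place of 3,4-dichlorophenyl on a carbon with a double bond to nitrogen.

Among the measured compounds shown here, only one measured step bears on this place: a 130-fold higher number from compound 1 to compound 3 (2.12 log units; beyond the scatter). That step is large and beyond the scatter, so this ring can clearly shift the number a long way. However, it involves a different pair of groups, and no measured compound carries the 3-bromo-4-hydroxyphenyl group, so the direction remains uncertain. The expected change in this assay is therefore moderate and leans towards a lower number, far smaller than the measured step: an estimated 2.7-fold lower number from compound 3 to compound 4 (0.42 log units; beyond the scatter). The estimate for compound 4 is 1000 nM, with an expected range from 120 nM to 6000 nM.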

Compound 4, half-maximal inhibitory concentration: 9250 nM
Compound 4: middle estimate off by 9.3-fold (0.97 log units), on the low side; the whole stated range lies below it.
By their numbers in this assay, from the lowest: compound 1; then compound 3; then compound 4.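

In this assay, replacing 3,4-dichlorophenyl with 3-bromo-4-hydroxyphenyl gives a 3.5-fold higher number from compound 3 to compound 4 (0.54 log units; beyond the scatter), so the number at this position still moves when one halogen-bearing ring replaces another with the same count of heavy atoms, here with a hydrogen-bond donor and acceptor entering. Measured from the 4-nitrophenyl ring of compound 1, the change is far larger, at a 460-fold higher number from compound 1 to compound 4 (2.67 log units; beyond the scatter), which leaves both halogen-bearing rings with a number well on the weaker side of the nitro-bearing ring, while compound 2 cannot be placed on this scale. Nothing available explains why the new ring gives a higher number than the dichlorinated one.

The change swaps one chlorine for bromine and the other for a hydroxyl group in a single step, so the compounds shown leave open which of these two swaps accounts for the rise, and a ring carrying only the bromine or only the hydroxyl group would separate them. They also leave open whether the low number of compound 1 is specific to the nitro group or would survive with an amine or a carboxylic acid in its place.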